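Swapping the Group on the Carbonyl of Compound 2

The source may report more compounds than this note shows. Statements on the series, on what has been measured and on what is new or still open speak of the compounds shown alone.

Compound 1 `Cc1ccc(/C=C/C(=O)Oc2ccc(/C=C3\CCCCC3=O)cc2)cc1`: 156000 nM
Compound 2 `Cc1ccc(/C=C/C(=O)Oc2ccc(/C=C3\CCCC(CN(C)C)C3=O)cc2)cc1`: 3390 nM
Compound 3 `Cc1ccc(C(=O)Oc2ccc(/C=C3\CCCCC3=O)cc2)cc1`: 25600 nM

In a functional assay on MOLT-4 cells (Homo sapiens) (on this read-out lower numbers stand for stronger inhibition and higher numbers for weaker inhibition), compound 2 has the lowest number of the three, at 3390 nM, which makes it the best inhibitor measured so far. The next compound to be tested is compound 4 `COc1ccc(C(=O)Oc2ccc(/C=C3\CCCC(CN(C)C)C3=O)cc2)cc1`, which is compound 2 with one group exchanged: 4-methoxyphenyl in place of 2-(4-methylphenyl)ethenyl on a carbonyl carbon. In words, 4-methoxyphenyl takes the place of 2-(4-methylphenyl)ethenyl on a carbonyl carbon.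

Among the compounds with values here, no measured step covers this exact exchange. Within the data shown here, the one measured step, a 46-fold lower number from compound 1 to compound 2 (1.66 log units; beyond the scatter), was large, but it concerns the added (dimethylamino)methyl group, a change elsewhere in the molecule. It shows that this group, which compound 4 keeps, went with a much lower number. The closest hint comes from two compounds without that group. Compound 1 gives 156000 nM, while compound 3, with a different and shorter group on the same carbonyl carbon, gives 25600 nM. Among the measured compounds shown here, that comparison points towards a lower number, though a modest one, since no measured compound carries 4-methoxyphenyl.

The expected change is a 2.3-fold lower number from compound 2 to compound 4 (0.35 log units; beyond the scatter). For compound 4, the estimated value is 1500 nM, with an expected range from 400 nM to 6000 nM.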

Compound 4, half-maximal inhibitory concentration: 2360 nM
Beside the measured number, compound 4's estimate is 1.6-fold (0.20 log units) below it; measured number inside the range.
By their numbers in this assay, from the lowest: compounds 4 and 2 (each within the scatter of the next); then compound 3; then compound 1.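

In this assay the exchange of 2-(4-methylphenyl)ethenyl for 4-methoxyphenyl gives a 1.4-fold lower number from compound 2 to compound 4 (0.16 log units; within the scatter) and so the two compounds read alike. Within the data shown here, this is the first exchange on this carbonyl carbon seen with the (dimethylamino)methyl group kept in place, and it shows that this position accepts two quite different groups with no difference that can be told from the scatter: the double bond outside the aromatic rings is gone in compound 4, and a hydrogen-bond acceptor has entered, yet neither separates compound 4 from compound 2. Nothing measured here bears on why these two groups read alike.

Because both groups carry a six-membered aromatic ring of carbon only, the compounds shown leave open whether such a ring is needed at all on this carbonyl carbon, or whether a plain methyl or a longer saturated chain would read the same. They also leave open how the number would respond if the methoxy group on the ring gave way to an amine or a carboxylic acid.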